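A few compounds are considered here, and "the series" means these few. Any claim that something is new, unique, unknown or untested is made for them only; others in the source may bear on it.

Measured compounds in an assay on cells for antagonist activity at transient receptor potential cation channel subfamily V member 1 (Homo sapiens), read by FLIPR and calcium flux, with a stated time of 6 min; on this read-out higher numbers stand for weaker inhibition and lower numbers for stronger inhibition:
compound 1 `CCCCCCOc1nc(C(C)(C)C)ccc1CNC(=O)C(C)c1ccc(NS(C)(=O)=O)c(F)c1` — 2.7 nM
compound 2 `CC(C)COc1nc(C(C)(C)C)ccc1CNC(=O)C(C)c1ccc(NS(C)(=O)=O)c(F)c1` — 0.6 nM

Compound 1 stands at the highest of the two numbers in this assay, giving 2.7 nM; the nearest is compound 2, which gives 0.6 nM, the two being separated by a 4.5-fold lower number from compound 1 to compound 2 (0.65 log units; beyond the scatter).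

Compound 3 `CC(C(=O)NCc1ccc(C(C)(C)C)nc1SCCCN1CCCC1)c1ccc(NS(C)(=O)=O)c(F)c1` differs from compound 1 by (3-(pyrrolidin-1-yl)propyl)sulfanyl in place of hexyloxy on an aromatic carbon.

Among the compounds with values here, the only measured step, a 4.5-fold lower number from compound 1 to compound 2 (0.65 log units; beyond the scatter), varies the saturated chain on the oxygen while the oxygen itself stays; it does not touch the change made in compound 3, where the oxygen-bearing group leaves altogether. Within the data shown here, no measured step therefore bears on this change, and its size and direction cannot be read from the series. A step of no more than modest size, in either direction, is expected, with a wide range kept around it.

Compound 3 is estimated at 8 nM, range 1.5 nM to 60 nM.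

This expected value would mean a 3.0-fold higher number from compound 1 to compound 3 (0.47 log units; beyond the scatter).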

Compound 3, inhibition constant: 17.1 nM
Compound 3: middle estimate off by 2.1-fold (0.33 log units), on the low side; low and high end bracket the measured number.
By their numbers in this assay, from the lowest: compound 2; then compound 1; then compound 3.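

In this assay, the aromatic carbon that holds an oxygen-linked chain in compound 1 and compound 2 also accepts (3-(pyrrolidin-1-yl)propyl)sulfanyl, though with weaker inhibition against both: a 6.3-fold higher number from compound 1 to compound 3 (0.80 log units; beyond the scatter) and a 29-fold higher number from compound 2 to compound 3 (1.45 log units; beyond the scatter). The loss is larger against isobutoxy than against hexyloxy, so the cost of this change depends on which chain it is measured from, and compound 3 gives the highest number of the three. Nothing available accounts for the direction or size of these steps.

On these data alone, the change replaces the linking oxygen with sulfur and alters the chain and its end all at once, so the share of each remains open. A hexylsulfanyl group, a 3-(pyrrolidin-1-yl)propoxy group or a propyl chain ending in a morpholine ring would help separate these contributions.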